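This account rests on a few compounds, and the source may have more. Where it says the series, first, only, none or still open, it means among the compounds named here.

Compound 1 `Cc1ccc(OC[C@@H]2CCN2)cn1`: 0.057 nM
Compound 2 `COc1ccc(OC[C@@H]2CCN2)cn1`: 1.3 nM
Compound 3 `Cc1cncc(OC[C@@H]2CCN2)c1`: 0.047 nM

In an assay on brain for binding affinity to Neuronal acetylcholine receptor; alpha4/beta2 (Rattus norvegicus), read by radioligand binding (a lower number here means a stronger inhibitor, a higher number a weaker inhibitor), compound 3 gives the lowest of the three numbers, though compound 1 sits within the scatter of it, while compound 2 lies well beyond. Compound 4 `c1ccc(-c2cncc(OC[C@@H]3CCN3)c2)cc1` differs from compound 3 by phenyl in place of methyl on an aromatic carbon. Among the compounds with values here, the only measured step, a 23-fold higher number from compound 1 to compound 2 (1.36 log units; beyond the scatter), swaps a methyl for a methoxy rather than a phenyl, so it does not bear directly on this change; it shows only that replacing the methyl here can shift the number a great deal. A moderate weakening is therefore expected, with an estimated 6.4-fold higher number from compound 3 to compound 4 (0.81 log units; beyond the scatter). For compound 4 the estimate in this assay is 0.3 nM. Its expected range runs from 0.05 nM to 2 nM.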

Compound 4, inhibition constant: 0.046 nM
Compound 4: the middle estimate sits 6.5-fold (0.81 log units) above what was measured; measured number below the stated range.
By their numbers in this assay, from the lowest: compounds 4, 3 and 1 (each within the scatter of the next); then compound 2.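

In this assay, the change at this aromatic carbon, two atoms from the ring nitrogen, gives a 1.0-fold lower number from compound 3 to compound 4 (0.01 log units; within the scatter), so phenyl and methyl cannot be told apart here. Going from 1 heavy atom to 6 heavy atoms, with a whole six-membered aromatic ring added, leaves the number within the scatter at this position. Nothing available explains this result. As far as these compounds go, what an amine, a carboxylic acid or a longer chain would do at this carbon remains open. So does whether a substituent such as a hydroxyl on the added phenyl would shift the number.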